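Replacing the 4-bromophenyl group of compound 2

A few compounds are considered here, and "the series" means these few. Any claim that something is new, unique, unknown or untested is made for them only; others in the source may bear on it.

Measured so far in a functional assay on MCF7 cells (Homo sapiens) for antiproliferative activity, read by MTT assay; a higher number here means a weaker inhibitor, a lower number a stronger inhibitor
compound 1 `Cc1c(-n2cc(COc3ccc(/C=C/C(=O)c4cc5c(cc4O)OC(C)(C)CC5)cc3)nn2)cccc1[N+](=O)[O-]` gives 176000 nM
compound 2 `CC1(C)CCc2c(ccc(C(=O)/C=C/c3ccc(OCc4cn(-c5ccc(Br)cc5)nn4)cc3)c2O)O1` gives "not active" (no number reported)

Compound 2 stands without a number, so it offers no anchor of its own. Compound 3 `COc1ccc(-n2cc(COc3ccc(/C=C/C(=O)c4ccc5c(c4O)CCC(C)(C)O5)cc3)nn2)c([N+](=O)[O-])c1` carries 4-methoxy-2-nitrophenyl in place of 4-bromophenyl on an aromatic nitrogen. In this assay, within the data shown here, a small step is expected, from no reported number towards weak but measurable inhibition, since compound 1 at 176000 nM is the only number. The expected value for compound 3 is 100000 nM (estimated range 30000 nM to 300000 nM).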

Compound 3, half-maximal inhibitory concentration: 73100 nM
For compound 3 the middle estimate is 1.4-fold (0.14 log units) above the measured one, within the range that was stated.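

Among these compounds, with no number for compound 2 in this assay, no step to compound 3 can be read. The compounds shown leave open what replacing 4-bromophenyl with 4-methoxy-2-nitrophenyl does to activity, and no supporting data bear on the result.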